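A Second Chloro on the Aryl Ring of Compound 3

The source may hold more compounds than are shown below. What is called first, only, known or untested is meant among the compounds shown, and "the series" means these compounds.

The measured compounds and their values in a physicochemical assay for lipophilicity; on this read-out lower numbers stand for lower lipophilicity and higher numbers for higher lipophilicity:
- compound 1, `Fc1ccccc1C1=NC(c2ccccc2)CO1`: 3.51
- compound 2, `Fc1cccc(Cl)c1C1=NC(c2ccccc2)CO1`: 3.45
- compound 3, `Clc1ccc(C2=NC(c3ccccc3)CO2)cc1`: 4.48

Compound 2 differs from compound 1 in one place, (chloro in place of hydrogen on an aromatic carbon). In this assay this gave a number 0.06 log units lower from compound 1 to compound 2 (within the scatter), so the two values cannot be told apart.

Compound 3 has the highest value of the three; compound 1 lies nearest to it and compound 2 furthest, and both gaps are beyond the scatter. How the core of compound 3 differs from the core of compound 1 is not broken down here.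

Compound 4, `Clc1ccc(C2=NC(c3ccccc3)CO2)c(Cl)c1`, has not yet been measured in this assay. It differs from compound 3 by chloro in place of hydrogen on an aromatic carbon. Among the measured compounds shown here, this is the same kind of change as the one from compound 1 to compound 2, but not the same: in compound 2 the entering chloro is meta to a fluoro group, whereas in compound 4 it is meta to a chloro group.

The account expects the step from compound 3 to compound 4 to be a number 0.17 log units higher from compound 3 to compound 4 (within the scatter), resting on compound 3 at 4.48 and on the near-flat step a number 0.06 log units lower from compound 1 to compound 2 (within the scatter), while allowing that the surroundings differ. Compound 4 is therefore estimated to give 4.65, between 4.25 and 5.15.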

Compound 4, partition coefficient: 4.4
Compound 4: the middle estimate sits 0.25 log units above what was measured; the measured number falls inside the stated range.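

In this assay, chloro in place of hydrogen on an aromatic carbon gave a number 0.08 log units lower from compound 3 to compound 4 (within the scatter) on the core of compound 3, and the same kind of change gave a number 0.06 log units lower from compound 1 to compound 2 (within the scatter) on the core of compound 1, so neither pair of values can be told apart. The step therefore carried over from one core to the other in these two pairs, with the result on each side lying within the usual scatter, but two pairs that differ in their surroundings establish no rule for the series and say nothing about how the change would read on any further core. No measurement shown accounts for why the step stays this small on either core.

The compounds shown carry only fluoro and chloro on the aryl ring, so it remains open whether a methoxy group, an amine or a carboxylic acid entering at the same place, ortho to a large group and meta to a chloro group, would also leave the value of compound 3 indistinguishable. Among the compounds shown here, it also remains open whether a longer chain at that place would read differently from the single chlorine atom in compound 4.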